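A methoxy added beside the aryl ether linkage

The compounds below may be only part of what the source reports. "The series", "measured", "known", "first", "only" and "open" are said of these compounds alone.

Of the compounds shown here, three have been measured so far. Compound 1 `C=C(C)[C@@H]1CC=C(Cn2cc(COc3ccc(C4NC(=O)NC(C)=C4C(=O)OCC)cc3)nn2)CC1` carries the ether linkage across from the shared core, and in a functional assay on MCF7 cells (Homo sapiens) for inhibition, read by sulforhodamine B assay, with a stated time of 48 h (a higher number here means a weaker inhibitor of growth, a lower number a stronger inhibitor of growth), compound 1 gives 43100 nM. Compound 2 `C=C(C)[C@@H]1CC=C(Cn2cc(COc3cccc(C4NC(=O)NC(C)=C4C(=O)OCC)c3)nn2)CC1` moves that linkage to another position of the same ring, and in this assay compound 2 gives 42500 nM. Among the two numbers shown, compound 2 has the lowest, but its nearest neighbour is compound 1 and the gap between them lies within the scatter, so the two cannot be ordered. Compound 3 `C=C(C)[C@@H]1CC=C(Cn2cc(COc3ccccc3C3NC(=O)NC(C)=C3C(=O)OCC)nn2)CC1` places the linkage immediately next to the core, and for compound 3 this assay reports only a limit, > 100000 nM. That limit, (the limit of > 100000 nM in this assay, at which 1 of the 3 values shown sits), is the one at which one of the three values sits.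

Compound 4 `C=C(C)[C@@H]1CC=C(Cn2cc(COc3cc(C4NC(=O)NC(C)=C4C(=O)OCC)ccc3OC)nn2)CC1` is not yet measured. It differs from compound 2 by methoxy in place of hydrogen on an aromatic carbon. For the measured compounds named here, no step between two measured compounds isolates such a change, so the expected size of the step from compound 2 rests on the change alone; a small step, if any, within the scatter in either direction seems most likely. The expected step is a 1.1-fold lower number from compound 2 to compound 4 (0.03 log units; within the scatter). Compound 4 is therefore estimated at 40000 nM, with a range from 15000 nM to 100000 nM.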

Compound 4, concentration for total growth inhibition: > 100000 nM
Compound 4: only a limit was reported (the forecaster's own chance of this, stated with the estimate: 25%); at least 2.5-fold (0.39 log units) between middle value and limit.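

In this assay, for the compounds shown here, the earlier compounds differed only in where the ether linkage sits on the ring, and no step between them isolated a single added group. The new result supplies that step for methoxy in place of hydrogen on an aromatic carbon, ortho to a large group and para to a large group: an at least 2.3-fold higher number from compound 2 to compound 4 (0.37 log units; beyond the scatter), which shows that this one addition, with the linkage left where it stands in compound 2, is enough to move the number beyond the scatter. The value of compound 4, > 100000 nM, is a limit of the assay and not a number, and the series now has a second compound at that limit: the limit of > 100000 nM in this assay, at which 2 of the 4 values shown sit.

The compounds shown leave open whether this step belongs to methoxy itself or would appear with any group on that carbon, such as a hydroxyl or a fluorine, and how large the step truly is. They also leave open whether the same methoxy on the ring of compound 1 would give a like step.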